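Chloro for Fluoro on Two Cores in Aorta Inhibition

This account rests on a few compounds, and the source may have more. Where it says the series, first, only, none or still open, it means among the compounds named here.

Compound 1 `O=C1C(Nc2ccc(F)cc2)=CC(=O)c2ncccc21`: 541 nM
Compound 2 `O=C1C(Nc2ccc(Cl)cc2)=CC(=O)c2ncccc21`: 178 nM
Compound 3 `O=C1C=C(Nc2ccc(F)cc2)C(=O)c2cnccc21`: 1230 nM

These values come from a functional assay (aorta) for inhibition, with Rattus norvegicus as the target; a lower number here means that less compound is needed, a higher number that more compound is needed for the effect. Compound 2 differs from compound 1 by chloro in place of fluoro on an aromatic carbon, and this change gave a 3.0-fold lower number from compound 1 to compound 2 (0.48 log units; beyond the scatter). Compound 3 has the same atoms as compound 1, joined differently; the difference between the two cores is not broken down here. Of the three measured compounds, compound 3 shows the highest number.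

Compound 4 `O=C1C=C(Nc2ccc(Cl)cc2)C(=O)c2cnccc21` has not yet been measured in this assay. It stands to compound 3 as compound 2 stands to compound 1, differing by chloro in place of fluoro on an aromatic carbon, the same change at the same kind of place.

Compound 4 is expected to give about 410 nM in this assay, between 180 nM and 950 nM, a step of a 3.0-fold lower number from compound 3 to compound 4 (0.48 log units; beyond the scatter), because the same change earlier gave a 3.0-fold lower number from compound 1 to compound 2 (0.48 log units; beyond the scatter).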

Compound 4, half-maximal effective concentration: 190 nM
Compound 4: the middle estimate sits 2.2-fold (0.33 log units) above what was measured; the range from low to high includes it.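

In this assay, chloro in place of fluoro on an aromatic carbon again lowered the number, giving a 6.5-fold lower number from compound 3 to compound 4 (0.81 log units; beyond the scatter) on the second core. Set beside the earlier step, the change goes the same way on both cores, and the two steps cannot be told apart: the same change on two cores in this assay, a 3.0-fold lower number (0.48 log units; beyond the scatter) from compound 1 to compound 2 and a 6.5-fold lower number (0.81 log units; beyond the scatter) from compound 3 to compound 4, 2.1-fold (0.33 log units) apart, within the scatter of two such steps. This shows that the change carried from one core to the other in this pair of matched compounds, but two pairs do not show that it would carry to further cores, nor do they explain why it lowers the number.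

The compounds shown hold only fluoro or chloro at this place. From the compounds shown here alone, whether bromo, methoxy or an amine there would behave in the same way remains open.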